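The source may report more compounds than this note shows. Statements on the series, on what has been measured and on what is new or still open speak of the compounds shown alone.

Measured in an assay on isolated protein for inhibition of N-acylethanolamine-hydrolyzing acid amidase (Homo sapiens), read by fluorescence, with a stated time of 90 min; on this read-out higher numbers stand for weaker inhibition and lower numbers for stronger inhibition:

compound 1, `Cc1ccc(-c2ccc(CO[C@H]3C[C@@H](N=C=S)C3)cc2)cc1`: 26 nM
compound 2, `COc1cnc(-c2ccc(CO[C@H]3C[C@@H](N=C=S)C3)cn2)cc1F`: 15 nM
compound 3, `Fc1cc(-c2ccc3c(c2)CCO3)ccc1CO[C@H]1C[C@@H](N=C=S)C1`: 4.5 nM

Compound 1 has the highest number of the three. Against compound 2 the gap is within the scatter; against compound 3 it is beyond the scatter, so compound 3 binds more strongly than compound 1 in this assay.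

Compound 4, `S=C=N[C@H]1C[C@@H](OCc2ccc(-c3ccccc3)cc2)C1`, is not yet measured. It differs from compound 1 by hydrogen in place of methyl on an aromatic carbon. For the measured compounds named here, no measured pair in this set shows that change, so the expected step cannot be read from a neighbour. A small step toward a higher number, at most on the edge of the scatter, is expected: a 1.5-fold higher number from compound 1 to compound 4 (0.19 log units; within the scatter). Compound 4 is estimated at 40 nM, range 15 nM to 110 nM.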

Compound 4, half-maximal inhibitory concentration: 93 nM
For compound 4 the middle estimate is 2.3-fold (0.37 log units) below the measured one; low and high end bracket the measured number.
By their numbers in this assay, from the lowest: compound 3; then compounds 2 and 1 (each within the scatter of the next); then compound 4.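

Hydrogen in place of methyl on an aromatic carbon, para to a large group, gives a 3.6-fold higher number from compound 1 to compound 4 (0.55 log units; beyond the scatter) in this assay, the only single-place step in the series so far. Losing 1 heavy atom at this position is thus enough to move the number beyond the scatter, so methyl and hydrogen are not interchangeable here. Nothing on hand explains the step.

Going by these compounds, whether ethyl, methoxy or chlorine at this position would match the methyl remains open. Also open, on these data alone, is whether the same change would give a similar step on the cores of compound 2 and compound 3.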